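A Fluorine Swap on the Ring Beside the Imine Carbon

This account rests on a few compounds, and the source may have more. Where it says the series, first, only, none or still open, it means among the compounds named here.

Of the compounds shown here, three on a shared core have been measured so far. Compound 1 `COc1cccc(/C=N/Nc2ncc3c(n2)n(C2CCCC2)c(=O)c(=O)n3C)c1` gives 20700 nM in a functional assay on PC-3 cells (Homo sapiens) for antiproliferative activity, read by MTT assay; a lower number here means a stronger inhibitor, a higher number a weaker inhibitor. Compound 2 `Cn1c(=O)c(=O)n(C2CCCC2)c2nc(N/N=C/c3ccc(C(F)(F)F)cc3)ncc21` gives 23600 nM, and compound 3 `COc1cc(/C=N/Nc2ncc3c(n2)n(C2CCCC2)c(=O)c(=O)n3C)cc(OC)c1OC` gives 17500 nM. All three numbers lie within the usual scatter of one another, so compound 2 cannot be set apart from compound 1 or compound 3 on these results. Going by the values given here, the only single-point step measured, a 1.1-fold higher number from compound 1 to compound 2 (0.06 log units; within the scatter), shows that exchanging one phenyl ring for another on the carbon with a double bond to nitrogen left the number essentially where it was.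

Compound 4 `Cn1c(=O)c(=O)n(C2CCCC2)c2nc(N/N=C/c3ccc(F)cc3F)ncc21` has not yet been measured. Among the compounds with values here, it differs from compound 2 in one place: 2,4-difluorophenyl in place of 4-(trifluoromethyl)phenyl on a carbon with a double bond to nitrogen Only the step from compound 1 to compound 2 bears on this change, since it alters the same phenyl ring at the same place, and that step stayed within the scatter. Within the data shown here, no measured pair shows one fluorine-bearing phenyl replaced by another. A step beyond the scatter is therefore not expected. For compound 4 the expected step is a 1.1-fold lower number from compound 2 to compound 4 (0.03 log units; within the scatter), and its value is estimated at 22000 nM, within a range from 10000 nM to 45000 nM.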

Compound 4, half-maximal inhibitory concentration: 13200 nM
The estimate for compound 4 lay 1.7-fold (0.22 log units) above the measured number; measured number inside the range.
By their numbers in this assay, from the lowest: compounds 4, 3, 1 and 2 (each within the scatter of the next).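

In this assay, going by these compounds alone, the step to the 2,4-difluorophenyl group gives the first measured exchange of one fluorine-bearing phenyl ring for another on the carbon with a double bond to nitrogen, and it reads a 1.8-fold lower number from compound 2 to compound 4 (0.25 log units; within the scatter), so trading the trifluoromethyl group for two separate fluorines does not move the number past the scatter. Set against the 3-methoxyphenyl group, the same ring gives a 1.6-fold lower number from compound 1 to compound 4 (0.20 log units; within the scatter), which means that a fluorine-bearing ring and a methoxy-bearing ring also cannot be told apart at this place, and that all three groups in these steps remain within the scatter of one another. Nothing available here explains why these exchanges leave the number so little changed.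

Going by these compounds, the phenyl rings compared here carry only methoxy, trifluoromethyl or fluorine groups, so it stays open whether a phenyl ring bearing an amine or a carboxylic acid would produce a step beyond the scatter. On these data alone, it is equally open whether this place needs a phenyl ring at all, since a pyridine ring or a longer carbon chain could behave quite differently.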